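The source may hold more compounds than are shown below. What is called first, only, known or untested is meant among the compounds shown, and "the series" means these compounds.

Measured in a physicochemical assay for lipophilicity, measured as octanol-water partition; on this read-out higher numbers stand for higher lipophilicity and lower numbers for lower lipophilicity:
- compound 1 `O=C(COc1cccc2ccccc12)N/N=C/c1ccc(O)cc1`: 3.73
- compound 2 `C/C(=N\NC(=O)COc1cccc2ccccc12)c1cccc([N+](=O)[O-])c1`: 3.37
- compound 3 `C/C(=N\NC(=O)COc1cccc2ccccc12)c1ccc(C#N)cc1Br`: 3.61

Compound 1 stands at the top of this small set, though not clearly alone. Its value of 3.73 lies within the usual scatter of compound 3 at 3.61. Only compound 2, at 3.37, sits lower than compound 1 by more than the scatter.

The next compound to be measured is compound 4 `O=C(COc1cccc2ccccc12)N/N=C/C=C/c1ccccc1`. It keeps the core of compound 1 and changes one group, with 2-phenylethenyl in place of 4-hydroxyphenyl on a carbon with a double bond to nitrogen.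

For the measured compounds named here, only one measured step bears on this, and only loosely. It is a number 0.24 log units higher from compound 2 to compound 3 (within the scatter), a swap of groups at the same kind of carbon, and it stays within the scatter. That step involves neither of the two groups in question, so it gives little guide to size. The group entering here holds only carbon, while the group leaving holds oxygen, and on that structural change alone a rise is expected, probably beyond the scatter.

The expected size of the change is a number 0.57 log units higher from compound 1 to compound 4 (beyond the scatter).

Compound 4 is estimated at 4.3, with an expected range from 3.8 to 4.8.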

Compound 4, partition coefficient: 4.43
The estimate for compound 4 lay 0.13 log units below the measured number; the range from low to high includes it.
By their numbers in this assay, from the lowest: compounds 2, 3 and 1 (each within the scatter of the next, the first and the last beyond it); then compound 4.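

At this position, on a carbon with a double bond to nitrogen, putting 2-phenylethenyl in place of 4-hydroxyphenyl gives a number 0.70 log units higher from compound 1 to compound 4 (beyond the scatter) in this assay, and this lifts compound 4 above the other three compounds. For the compounds shown here, the only earlier step between measured compounds, a number 0.24 log units higher from compound 2 to compound 3 (within the scatter), stayed within the scatter, so this is the first single change in the set to move the number by more than repeat measurements would. The entering group is all carbon and has no hydrogen-bond donors or acceptors, but nothing shown establishes what drives the rise.

The swap removes the hydroxyl and adds a double bond outside the aromatic ring in one move, so the compounds shown cannot separate these two changes, and a plain phenyl or a 4-methoxyphenyl group at the same place would help to tell them apart. Also open, on these data alone, is how the number would respond to a longer all-carbon chain at this place, or to an amine or a carboxylic acid on the ring of the 2-phenylethenyl group.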